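This account rests on a few compounds, and the source may have more. Where it says the series, first, only, none or still open, it means among the compounds named here.

Measured so far:
- compound 2 `COC(=O)/C(=C/c1ccccc1)CN1C(=O)[C@@H](OC)[C@H]1c1ccc(OC)cc1`: 11600 nM in a functional assay on MCF7 cells (Homo sapiens) for antiproliferative activity, read by MTT assay, with a stated time of 48 h; on this read-out higher numbers stand for weaker inhibition and lower numbers for stronger inhibition
- compound 1 `COC(=O)/C(=C/c1ccccc1)CN1C(=O)[C@@H](OC)[C@H]1c1cccc(C(F)(F)F)c1`: no result reported in this assay

Within the data shown here, compound 2 carries the only number in this assay; compound 1 has no single value, so nothing can be said of how the two stand to each other, and no step between measured compounds is available.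

Compound 3 `COC(=O)/C(=C/c1ccccc1)CN1C(=O)[C@@H](OC)[C@H]1c1cccc(Cl)c1` differs from compound 2 at one place: 3-chlorophenyl in place of 4-methoxyphenyl on a saturated ring carbon. Without any measured step involving a change of this kind, there is no basis for expecting a shift beyond the scatter in either direction; the working expectation is a step from compound 2 to compound 3 of a 1.3-fold lower number from compound 2 to compound 3 (0.11 log units; within the scatter), i.e. essentially none.

Compound 3 is therefore estimated at 9000 nM in this assay, with a range from 3000 nM to 30000 nM, broad to reflect that the expectation rests on a single measured compound.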

Compound 3, half-maximal inhibitory concentration: 25100 nM
Compound 3: the middle estimate sits 2.8-fold (0.45 log units) below what was measured; measured number inside the range.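

In this assay, 3-chlorophenyl in place of 4-methoxyphenyl on the saturated ring carbon gives a 2.2-fold higher number from compound 2 to compound 3 (0.34 log units; beyond the scatter), so inhibition is weaker with the new group. This first readable step shows that the aryl group at this position can move the read-out beyond the usual scatter, although the shift is modest. Nothing at hand accounts for the shift.

The step changes both the substituent and its place on the phenyl ring, so the contributions of the two changes cannot be separated, and steps involving compound 1 cannot be read. Going by these compounds, how a plain phenyl, or a phenyl carrying an amine or a carboxylic acid, would stand against compound 2 and compound 3 remains open.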